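Predicting a Fourth Analogue from Three Measured Ones

A few compounds are considered here, and "the series" means these few. Any claim that something is new, unique, unknown or untested is made for them only; others in the source may bear on it.

Compound 1 `Cc1ccc(-c2nc(SCc3cn(CC(=O)NC(=O)Nc4ccccn4)nn3)nc(Nc3ccc(C(C)C)cc3)c2C#N)cc1` gives 19300 nM in a functional assay on MGC-803 cells (Homo sapiens) for inhibition, read by MTT assay, with a stated time of 72 h; a lower number here means a stronger inhibitor, a higher number a weaker inhibitor.
Compound 2 `Cc1ccc(-c2nc(SCc3cn(CC(=O)NC(=O)Nc4ccccn4)nn3)nc(Nc3cccc(C(F)(F)F)c3)c2C#N)cc1` gives 7580 nM in this assay.
Compound 3 `N#Cc1c(Nc2cccc(C(F)(F)F)c2)nc(SCc2cn(CC(=O)NC(=O)Nc3ccccn3)nn2)nc1-c1ccc(Br)cc1` gives 3600 nM in this assay.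

Compound 3 holds the lowest of these three numbers. Compound 4 `CC(C)c1ccc(Nc2nc(SCc3cn(CC(=O)NC(=O)Nc4ccccn4)nn3)nc(-c3ccc(Br)cc3)c2C#N)cc1` has not been measured; it differs from compound 3 by 4-isopropylphenyl in place of 3-(trifluoromethyl)phenyl on a nitrogen on an aromatic ring. This exchange has been made once before among these compounds, where it gave a 2.5-fold higher number from compound 2 to compound 1 (0.41 log units; beyond the scatter). The cores on which the two exchanges sit differ by bromo in place of methyl on an aromatic carbon, a change that gave a 2.1-fold lower number from compound 2 to compound 3 (0.32 log units; beyond the scatter). The two places of the exchange read the same word for word, so the change is the same change, set on a core carrying bromo instead of methyl. For the measured compounds named here, the step from compound 3 to compound 4 is expected to be a 2.5-fold higher number from compound 3 to compound 4 (0.40 log units; beyond the scatter), a weakening resting on the single earlier step of a 2.5-fold higher number from compound 2 to compound 1 (0.41 log units; beyond the scatter). Compound 4 is therefore expected to give 9000 nM, with a range from 4000 nM to 20000 nM.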

Compound 4, half-maximal inhibitory concentration: 15600 nM
For compound 4 the middle estimate is 1.7-fold (0.24 log units) below the measured one; low and high end bracket the measured number.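

In this assay, putting 4-isopropylphenyl in place of 3-(trifluoromethyl)phenyl on the bromo core gives a 4.3-fold higher number from compound 3 to compound 4 (0.64 log units; beyond the scatter), and this matches the same change on the methyl core: the same change on two cores in this assay, a 2.5-fold higher number (0.41 log units; beyond the scatter) from compound 2 to compound 1 and a 4.3-fold higher number (0.64 log units; beyond the scatter) from compound 3 to compound 4, 1.7-fold (0.23 log units) apart, within the scatter of two such steps

Bromo in place of methyl on the 4-isopropylphenyl compounds gives a 1.2-fold lower number from compound 1 to compound 4 (0.09 log units; within the scatter), and this too cannot be told apart from the earlier case: the same change on two cores in this assay, a 2.1-fold lower number (0.32 log units; beyond the scatter) from compound 2 to compound 3 and a 1.2-fold lower number (0.09 log units; within the scatter) from compound 1 to compound 4, 1.7-fold (0.23 log units) apart, within the scatter of two such steps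

So across these four compounds each change carries from one core to the other, but this rests on a single pair of cores and does not show why either change moves the number. Still open, going by these compounds, is whether the same holds for other groups on that nitrogen, such as a phenyl ring carrying a carboxylic acid or an amine. On these data alone, a chloro group in place of bromo, or a longer chain in place of methyl, is equally open.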